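A 1,3-thiazol-2-yl group replaces cyclopentyl

The source may hold more compounds than are shown below. What is called first, only, known or untested is meant among the compounds shown, and "the series" means these compounds.

Three measured compounds share one core and differ in a single group on an aromatic carbon. In a physicochemical assay for solubility, in phosphate buffer, with a stated time of 18 h (a higher number here means a more soluble compound, a lower number a less soluble compound), compound 1 `CSc1nc(C(C)(C)C)nc2nc(N)c(C#N)c(N)c12` gives 14000 nM. Compound 2 `CC(C)(C)c1nc(CCCCCC#N)c2c(N)c(C#N)c(N)nc2n1` gives 6000 nM, which is a 2.3-fold lower number from compound 1 to compound 2 (0.37 log units; beyond the scatter). Compound 3 `CC(C)(C)c1nc(C2CCCC2)c2c(N)c(C#N)c(N)nc2n1` reads < 1000 nM, and this is a limit of the assay, not a number. Even so, the cyclopentyl group gives the lowest reading of the three, with an at least 14-fold lower number from compound 1 to compound 3 (1.14 log units; beyond the scatter) and an at least 6.0-fold lower number from compound 2 to compound 3 (0.77 log units; beyond the scatter).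

Compound 4 `CC(C)(C)c1nc(-c2nccs2)c2c(N)c(C#N)c(N)nc2n1` carries 1,3-thiazol-2-yl in place of cyclopentyl on an aromatic carbon. All three measured steps change this same place, so the group there clearly matters in this assay. Among the compounds with values here, no measured compound has an aromatic ring at this place, however, so the direction of the step is uncertain. Compound 4 keeps a five-membered ring, as compound 3 does, so it is expected to stay nearer compound 3 than compound 2, which sits at 6000 nM. A small rise is the more likely outcome, and another limit reading is quite possible. The expected size of the change is an at least 1.5-fold higher number from compound 3 to compound 4 (0.17 log units; that floor lies within the scatter). For compound 4 the estimated solubility is 1500 nM, with an expected range of 600 nM to 5000 nM.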

Compound 4, solubility: < 1500 nM
Compound 4: only a limit was reported; the forecaster's own chance of this, stated with the estimate: 45%; the middle value sits exactly at the limit.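

In this assay compound 4 reads < 1500 nM, which is a limit of the assay and not a number. The step still adds something new, as 1,3-thiazol-2-yl is the only aromatic ring among the groups shown on this aromatic carbon, and it too falls well short of the chain and the methylsulfanyl group, with an at least 4.0-fold lower number from compound 2 to compound 4 (0.60 log units; beyond the scatter) and an at least 9.3-fold lower number from compound 1 to compound 4 (0.97 log units; beyond the scatter). So both five-membered rings at this place, the non-aromatic carbon ring of cyclopentyl and the aromatic ring with hetero atoms of 1,3-thiazol-2-yl, give only limit readings, even though hydrogen-bond acceptors enter with the second and none are present in the first.

As far as these compounds go, the step from compound 3 to compound 4 cannot be read, as both readings are limits, so which of the two rings gives the higher number remains unknown. Also open, from the compounds shown here alone, is whether an amine or a carboxylic acid on this aromatic carbon, or a chain shorter than 5-cyanopentyl, would bring the reading back towards that of compound 1.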